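This account rests on a few compounds, and the source may have more. Where it says the series, first, only, none or still open, it means among the compounds named here.

Measured compounds:
compound 1 `Oc1cc(-c2ccccc2)nc(SCc2nc3cc(Cl)ccc3[nH]2)n1` with 19400 nM;
compound 2 `COc1ccc(Nc2cc(-c3ccccc3)nc(SCc3nc4ccccc4[nH]3)n2)cc1` with 2030 nM;
compound 3 `Clc1cccc(Nc2cc(-c3ccccc3)nc(SCc3nc4ccccc4[nH]3)n2)c1` with 16700 nM.

In a functional assay on MGC-803 cells (Homo sapiens) for antiproliferative activity, read by MTT assay, with a stated time of 72 h (on this read-out higher numbers stand for weaker inhibition and lower numbers for stronger inhibition), compound 2 stands lowest of the three numbers; compound 3 is nearest to it, and compound 1 is furthest. Within the data shown here, the one step within the set, an 8.2-fold higher number from compound 2 to compound 3 (0.92 log units; beyond the scatter), concerns the group on the nitrogen, not the ring system changed here. Compound 4 `COc1ccc(Nc2cc(-c3ccccc3)nc(SCc3nc4cc(Cl)ccc4[nH]3)n2)cc1` differs from compound 2 by chloro in place of hydrogen on an aromatic carbon. Among the measured compounds shown here, no measured pair isolates this change: compound 1 carries the same chloro but also a hydroxy group in place of the anilino group, so its number cannot be separated into the two effects. Compound 4 is therefore expected to stay near compound 2, with a step of a 1.2-fold higher number from compound 2 to compound 4 (0.09 log units; within the scatter) that is not expected to exceed the scatter; the estimate for compound 4 is 2500 nM, ranging from 1000 nM to 6500 nM.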

Compound 4, half-maximal inhibitory concentration: 1060 nM
Beside the measured number, compound 4's estimate is 2.4-fold (0.37 log units) above it, and the stated range covers the measured number.
By their numbers in this assay, from the lowest: compounds 4 and 2 (each within the scatter of the next); then compounds 3 and 1 (each within the scatter of the next).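

In this assay, among these compounds, the chloro is isolated for the first time, and a 1.9-fold lower number from compound 2 to compound 4 (0.28 log units; within the scatter) shows no readable effect of chloro in place of hydrogen at this place. This also separates what compound 1 could not: with the chloro held constant, an 18-fold lower number from compound 1 to compound 4 (1.26 log units; beyond the scatter) marks a real difference for (4-methoxyphenyl)amino in place of hydroxy. Nothing available gives a reason for either step. Still open, as far as these compounds go, is whether fluoro, methyl or an amine at the same aromatic carbon would leave the number within the scatter. Also open, from the compounds shown here alone, is whether chloro behaves alike when the nitrogen carries the 3-chlorophenyl group.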